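Purine benzamides: arylamino exchanged for methylpiperidine at the core

The compounds below may be only part of what the source reports. "The series", "measured", "known", "first", "only" and "open" are said of these compounds alone.

Going by the values given here, compound 2 `Nc1ccccc1NC(=O)c1ccc(Cn2cnc3c(Nc4cccc(OC(F)(F)F)c4)nc(Cl)nc32)cc1` stands highest of the two numbers measured so far; in a functional assay on NCI-H460 cells (Homo sapiens) for antiproliferative activity, read by CCK-8 assay, with a stated time of 72 h, tested at 8 uM (on this read-out higher numbers stand for a stronger effect at the one concentration tested and lower numbers for a weaker effect), compound 2 gives 62.4%. Compound 1 `Nc1ccccc1NC(=O)c1ccc(Cn2cnc3c(Nc4ccc(-c5ccccn5)cc4)nc(Cl)nc32)cc1` gives 30.8%. Among the compounds with values here, the single measured step, a number 31.6 percentage points higher from compound 1 to compound 2 (beyond the scatter), shows that the group at this position of the shared core moves the read-out strongly. Compound 3 `CC1CCN(c2nc(Cl)nc3c2ncn3Cc2ccc(C(=O)Nc3ccccc3N)cc2)CC1` differs from compound 2 by 4-methylpiperidin-1-yl in place of (3-(trifluoromethoxy)phenyl)amino on an aromatic carbon. Within the data shown here, no measured step exchanges an arylamino for a saturated amine, so the direction is uncertain; a downward step of a number 22.4 percentage points lower from compound 2 to compound 3 (beyond the scatter) is expected. Compound 3 is estimated at 40%, within 15% to 68%.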

Compound 3, a percentage reported as inhibition, at one concentration (the size of the read-out at that concentration, not a potency): 40.9%
Estimate against measurement, compound 3: 0.9 percentage points below; low and high end bracket the measured number.
By their numbers in this assay, from the lowest: compound 1; then compound 3; then compound 2.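

In this assay, the exchange gives a number 21.5 percentage points lower from compound 2 to compound 3 (beyond the scatter), so this position on the shared core has now been probed with a saturated amine as well as with arylamino groups. With no aromatic ring and 0 hydrogen-bond donors in the entering group, compound 3 still reaches 40.9%. No supporting data bear on the reason for this step.

Going by these compounds alone, the single exchange cannot separate loss of the aromatic ring from loss of the amino hydrogen. On these data alone, a cyclohexylamino group, or a morpholine or piperazine in place of 4-methylpiperidin-1-yl, remains open.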